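Aryl swap on the saturated ring carbon, clearance

The source may report more compounds than this note shows. Statements on the series, on what has been measured and on what is new or still open speak of the compounds shown alone.

Compound 2 `Cc1cccnc1N(C(=O)N1CCC(c2cnn3cccnc23)CC1)[C@@H]1CCCNC1` gives < 8 mL.min-1.g-1 in an ADME assay on microsomes from liver (Homo sapiens) for metabolic stability (on this read-out lower numbers stand for slow clearance and higher numbers for fast clearance), a limit rather than a number. Compound 1 `Cc1cccnc1N(C(=O)N1CCC(c2ccccc2)CC1)[C@@H]1CCCNC1` likewise returns a limit, < 8 mL.min-1.g-1. The step that the two limits leave unreadable from compound 1 to compound 2 cannot be sized because of the limit of < 8 mL.min-1.g-1 in this assay, at which 2 of the 2 values shown sit. Compound 3 `Cc1cccnc1N(C(=O)N1CCC(c2ccccc2F)CC1)[C@@H]1CCCNC1` differs from compound 2 by a group of 7 heavy atoms (6 carbon, 1 fluorine; one six-membered aromatic ring of carbon only) in place of a group of 9 heavy atoms (6 carbon, 3 nitrogen; one five-membered aromatic ring with 2 hetero atoms, one six-membered aromatic ring with 2 hetero atoms), on a saturated ring carbon. For the measured compounds named here, the one measured step bears on this change, yet it gives no readable size, so nothing beyond the scatter is expected in either direction. Compound 3 is expected to remain at or near the limit, with a step that the limit leaves unreadable from compound 2 to compound 3 estimated as small. Compound 3 is estimated at 6 mL.min-1.g-1, within 3 mL.min-1.g-1 to 14 mL.min-1.g-1.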

Compound 3, intrinsic clearance in microsomes in the Homo sapiens assay: < 8 mL.min-1.g-1
Compound 3 ended at the assay's limit; the forecaster's own chance of this, stated with the estimate: 70%; the middle value does not contradict the limit.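

For the compounds shown here, in the Homo sapiens assay compound 1, compound 2 and compound 3 all return a limit, and no step among them can be read: the limit of < 8 mL.min-1.g-1 in the Homo sapiens assay, at which 3 of the 3 values shown sit. In a physicochemical assay for lipophilicity, using the shake flask method (on this read-out higher numbers stand for higher lipophilicity and lower numbers for lower lipophilicity), compound 2 gives 0.2 and compound 3 gives 1. Whether clearance differs among these three compounds remains open.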